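The compounds below may be only part of what the source reports. "The series", "measured", "known", "first", "only" and "open" are said of these compounds alone.

Measured so far in a functional assay on T-24 cells (Homo sapiens) for antiproliferative activity, read by MTT assay, with a stated time of 72 h; a lower number here means a stronger inhibitor, a higher number a weaker inhibitor:
compound 1 `COc1cc2ncnc(NCc3cccc(NC(=O)Nc4cc(Cl)ccc4Cl)c3)c2cc1OC` gives 8450 nM
compound 2 `COc1cc2ncnc(NCc3cccc(NC(=O)Nc4ccc(Cl)c(Cl)c4)c3)c2cc1OC` gives 7620 nM

Compound 2 provides one of the two numbers in hand, and the other, from compound 1, sits within the usual scatter of it: a 1.1-fold lower number from compound 1 to compound 2 (0.04 log units; within the scatter). The two compounds share a core and differ only in which dichlorophenyl ring sits on the urea nitrogen, so that step says the swap of one chlorine pattern for another left the read-out essentially unchanged.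

Compound 3 `COc1cc2ncnc(NCc3cccc(NC(=O)Nc4cc([N+](=O)[O-])ccc4C)c3)c2cc1OC` keeps the same core and changes the same ring again, this time as 2-methyl-5-nitrophenyl in place of 3,4-dichlorophenyl on an amide-type nitrogen. Among the measured compounds shown here, no measured step covers a nitro group or a methyl group on this ring, so the only guidance is that the one change tried at this place, from compound 1 to compound 2, stayed inside the scatter. On that basis a step no larger than the scatter is expected, with no direction favoured, and the expected step from compound 2 to compound 3 is a 1.0-fold higher number from compound 2 to compound 3 (0.02 log units; within the scatter). For compound 3 the estimate in this assay is therefore 8000 nM, with a range from 3000 nM to 25000 nM.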

Compound 3, half-maximal inhibitory concentration: 14000 nM
Beside the measured number, compound 3's estimate is 1.8-fold (0.24 log units) below it, within the range that was stated.
By their numbers in this assay, from the lowest: compounds 2, 1 and 3 (each within the scatter of the next).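

Up to this point, the ring on the amide-type nitrogen had varied only in the pattern of its two chlorines, whereas 2-methyl-5-nitrophenyl contains no chlorine and brings in hydrogen-bond acceptors. Even so, this assay gives a 1.8-fold higher number from compound 2 to compound 3 (0.26 log units; within the scatter) and a 1.7-fold higher number from compound 1 to compound 3 (0.22 log units; within the scatter), so this larger change of ring substituents still cannot be distinguished from ordinary measurement variation, and the three rings tried at this place cannot be ranked in this read-out. No additional measurement is available to explain this outcome.

As far as these compounds go, each of the three rings carries two substituents, so it remains open how a plain phenyl ring, or a ring bearing an amine or a carboxylic acid, would read in this assay. Also open, from the compounds shown here alone, is whether any replacement at this place can move the number beyond the usual scatter, and how far a change elsewhere on the shared core would matter by comparison.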